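Chain branching at the limit: compound 3 to compound 4

The source may report more compounds than this note shows. Statements on the series, on what has been measured and on what is new or still open speak of the compounds shown alone.

Compound 1 `CCn1c(=O)[nH]c(=O)c2[nH]c(-c3cnn(Cc4ccccc4)c3)nc21` has no result in an assay on CHO cells for displacement of a labelled ligand from adenosine receptor A3 (Homo sapiens); a higher number here means a weaker inhibitor, a lower number a stronger inhibitor ("not determined" (no result reported)). Compound 2 `CCCn1c(=O)[nH]c2nc(-c3cnn(Cc4ccccc4)c3)[nH]c2c1=O` gives 120 nM in this assay. Compound 3 `CCCCn1c(=O)[nH]c2nc(-c3cnn(Cc4cccc(C(F)(F)F)c4)c3)[nH]c2c1=O` stands at a limit of this assay, reported only as > 9000 nM and not as a number. Of the three entries, compound 3 is the one at the limit of > 9000 nM in this assay, at which 1 of the 3 values shown sits. Compound 4 `CC(C)Cn1c(=O)[nH]c2nc(-c3cnn(Cc4cccc(C(F)(F)F)c4)c3)[nH]c2c1=O` differs from compound 3 by isopropyl in place of propyl on a saturated chain carbon bound to an aromatic nitrogen. Among the compounds with values here, no measured pair shows this change alone, so its size is not known here; a step of this kind is expected to be small, with no direction beyond the scatter. Compound 4 is therefore estimated at 12000 nM, within 4000 nM to 40000 nM, and most likely again only a limit. The step from compound 3 to compound 4 is expected to be a step that the limit leaves unreadable from compound 3 to compound 4.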

Compound 4, inhibition constant: > 9000 nM
Compound 4: a limit, no number; the forecaster's own chance of this, stated with the estimate: 70%; the middle value lies beyond the limit too.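

Compound 3 and compound 4 are both limits and not numbers, so no step between them can be read: the limit of > 9000 nM in this assay, at which 2 of the 4 values shown sit.

The compounds shown leave open what the change from butyl to isobutyl does by itself where the values on both sides are numbers.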